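Lengthening a side chain on a receptor agonist

This account rests on a few compounds, and the source may have more. Where it says the series, first, only, none or still open, it means among the compounds named here.

Compound 2 `CCCCCCN1C(=O)[C@H](Cc2ccc(-c3cccc(CN(CCCC)C(=O)NC)c3)cc2)N(C)C(=O)[C@@H]1C` has the lower number of the two measured compounds: in a functional assay on cells for agonist activity at follicle-stimulating hormone receptor (Homo sapiens), read by cAMP accumulation (a lower number here means that less compound is needed, a higher number that more compound is needed for the effect), compound 2 gives 9.5 nM. Compound 1 `CCCCCCCCN1C(=O)[C@H](Cc2ccc(-c3cccc(CN(CCCC)C(C)=O)c3)cc2)N(C)C(=O)[C@@H]1C` differs from it in two places and gives 35 nM in this assay, a gap beyond the usual scatter. Compound 3 `CCCCCCCCN1C(=O)[C@H](Cc2ccc(-c3cccc(CN(CCCC)C(=O)NC)c3)cc2)N(C)C(=O)[C@@H]1C` alters compound 2 at a single place: ethyl in place of hydrogen on a saturated chain carbon, six bonds along the chain from an amide-type nitrogen in a ring. Among the compounds with values here, no measured pair isolates this one change, so its direction is uncertain; a step no larger than the scatter is expected, a 1.3-fold higher number from compound 2 to compound 3 (0.10 log units; within the scatter). Compound 3 is therefore estimated to give 12 nM in this assay, within 5 nM to 30 nM.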

Compound 3, half-maximal effective concentration: 7.9 nM
Estimate against measurement, compound 3: 1.5-fold (0.18 log units) above; the measured number falls inside the stated range.
By their numbers in this assay, from the lowest: compounds 3 and 2 (each within the scatter of the next); then compound 1.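

In this assay putting ethyl in place of hydrogen on this saturated chain carbon gives a 1.2-fold lower number from compound 2 to compound 3 (0.08 log units; within the scatter) and so adds chain length with no change beyond the scatter. Methylamino in place of methyl on a carbonyl carbon gives a 4.4-fold lower number from compound 1 to compound 3 (0.65 log units; beyond the scatter) and thus shows that change alone, whereas compounds 1 and 2 differ in two places. No measurement here explains either step.

Still open, from the compounds shown here alone, is whether a longer chain, or a chain ending in a carboxylic acid or an amine, would hold the number at this position. Ethylamino on the same carbonyl carbon also remains untested in the compounds shown.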